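From Chloro to Methoxy: Expecting Compound 4

The source may report more compounds than this note shows. Statements on the series, on what has been measured and on what is new or still open speak of the compounds shown alone.

In a functional assay on U-87MG ATCC cells for antiproliferative activity against U-87 MG (Homo sapiens), read by MTT assay, with a stated time of 48 h (a lower number here means a stronger inhibitor, a higher number a weaker inhibitor), compound 3 (`Cc1nc(-c2ccc(Cl)cc2)sc1C(=O)CSc1nc(N)c(C#N)c(-c2ccc(Cl)cc2)n1`) gives 3420 nM and holds the middle place of three. Compound 1 (`COc1ccc(-c2nc(SCC(=O)c3sc(-c4ccccc4)nc3C)nc(N)c2C#N)cc1`) gives 14000 nM, the highest number of the three, and compound 2 (`COc1ccc(-c2nc(C)c(C(=O)CSc3nc(N)c(C#N)c(-c4ccc(OC)cc4)n3)s2)cc1`) gives 1560 nM, the nearest neighbour of compound 3. Compound 4 (`COc1ccc(-c2nc(SCC(=O)c3sc(-c4ccc(Cl)cc4)nc3C)nc(N)c2C#N)cc1`) differs from compound 3 in one place (methoxy in place of chloro on an aromatic carbon): methoxy in place of chloro on an aromatic carbon, 4-chlorophenyl to 4-methoxyphenyl. Going by the values given here, no measured step makes this exchange. The closest is modest (a 9.0-fold lower number from compound 1 to compound 2 (0.95 log units; beyond the scatter)) and puts methoxy in place of hydrogen on an aromatic carbon. Compound 4 takes only one of the two chloro-to-methoxy exchanges that separate compound 3 from compound 2 (1560 nM) so in this assay no shift beyond the scatter is expected. The estimated step is small (a 1.5-fold lower number from compound 3 to compound 4 (0.17 log units; within the scatter)) and points toward lower numbers. Compound 4 is estimated at 2300 nM within an expected range (800 nM to 7000 nM).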

Compound 4, half-maximal inhibitory concentration: 10600 nM
Compound 4: middle estimate off by 4.6-fold (0.66 log units), on the low side, and the stated range ends below it.
By their numbers in this assay, from the lowest: compound 2; then compound 3; then compounds 4 and 1 (each within the scatter of the next).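

In this assay, methoxy in place of chloro at this position raises the number (a 3.1-fold higher number from compound 3 to compound 4 (0.49 log units; beyond the scatter)), the opposite direction to the earlier methoxy step. On the other aromatic ring, chloro in place of methoxy also raises it (a 6.8-fold higher number from compound 2 to compound 4 (0.83 log units; beyond the scatter)), so the two rings answer the same exchange in opposite directions. On that ring, chloro in place of hydrogen gives a step within the scatter (a 1.3-fold lower number from compound 1 to compound 4 (0.12 log units; within the scatter)). The data offer no explanation for this reversal. The compounds shown leave open how an amine or a hydroxyl group would behave at either ring.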